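This account rests on a few compounds, and the source may have more. Where it says the series, first, only, none or still open, it means among the compounds named here.

Working notes on the series. In a functional assay on DU-145 cells (Homo sapiens) for cytotoxicity, read by MTT assay, with a stated time of 48 h (on this read-out lower numbers stand for stronger inhibition and higher numbers for weaker inhibition), compound 3 `COc1cc(COCc2cn(Cc3cc(-c4ccccc4)cnc3Cl)nn2)cc(OC)c1OC` gives 45500 nM, and compound 1 `COc1cc(COCc2cn(Cc3cc(-c4ccc(C)cc4)cnc3Cl)nn2)cc(OC)c1OC` gives 37000 nM. The two share one core and differ in a single place, (methyl in place of hydrogen on an aromatic carbon), and the step of a 1.2-fold lower number from compound 3 to compound 1 (0.09 log units; within the scatter) is small. Compound 2 `COc1cc(C2=NOC(COCc3cn(Cc4cc(-c5ccccc5)cnc4Cl)nn3)C2)cc(OC)c1OC` is built on another core; the difference between the core of compound 2 and the core of compound 3 is not broken down here. In this assay compound 2 gives 11400 nM, the lowest of the three numbers, with compound 1 the nearest and compound 3 the furthest, both gaps beyond the usual scatter.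

Compound 4 `COc1cc(C2=NOC(COCc3cn(Cc4cc(-c5ccc(C)cc5)cnc4Cl)nn3)C2)cc(OC)c1OC` has not been measured yet. It stands to compound 2 as compound 1 stands to compound 3: the change is methyl in place of hydrogen on an aromatic carbon, at the same place as before, so it is the same change applied to the core of compound 2. For the measured compounds named here, only one earlier step of this kind is available, and it stayed within the scatter. Whether the change reads the same on the core of compound 2 cannot be checked from the measured compounds. For compound 4 the corresponding step is estimated as a 1.2-fold lower number from compound 2 to compound 4 (0.08 log units; within the scatter) because the measured pair showed a 1.2-fold lower number from compound 3 to compound 1 (0.09 log units; within the scatter). For compound 4 the estimate in this assay is 9500 nM, with a range from 4500 nM to 20000 nM.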

Compound 4, half-maximal inhibitory concentration: 13100 nM
Estimate against measurement, compound 4: 1.4-fold (0.14 log units) below; the measured number falls inside the stated range.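

On the core of compound 2, the change from phenyl to 4-methylphenyl gives a small step in this assay, a 1.1-fold higher number from compound 2 to compound 4 (0.06 log units; within the scatter). Set beside the step on the core of compound 3, the change reads alike on both cores, and no difference between the two cores can be told from the scatter: the same change on two cores in this assay, a 1.2-fold lower number (0.09 log units; within the scatter) from compound 3 to compound 1 and a 1.1-fold higher number (0.06 log units; within the scatter) from compound 2 to compound 4, 1.4-fold (0.15 log units) apart, within the scatter of two such steps For this one change at this one place, the two pairs therefore agree in showing no step beyond the scatter, but they do not show that a change with a clear step would carry over in the same way, and two pairs in one assay make no rule for other groups or other cores.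

The compounds shown leave open whether another group at the same place, such as an amine, a carboxylic acid or a longer chain, would give a step beyond the scatter in this assay, and whether such a step would keep its size from the core of compound 3 to the core of compound 2. They also leave open whether the agreement between the two cores holds for the methyl change on any read-out other than this one.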